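A few compounds are considered here, and "the series" means these few. Any claim that something is new, unique, unknown or untested is made for them only; others in the source may bear on it.

Measured so far:

- compound 1, `O=C1O/C(=C\Cn2cc(C3=CCCCC3)nn2)C(OCc2ccccc2)=C1OCc1ccccc1`: > 100000 nM
- compound 2, `Cc1ccc(-c2cn(CCC3(O)NC(=O)C(OCc4ccccc4)=C3OCc3ccccc3)nn2)cc1`: 24000 nM
- compound 3, `CCCc1cn(CCC2(O)C(OCc3ccccc3)=C(OCc3ccccc3)C(=O)N2CCC)nn1`: > 100000 nM

All three were tested in a functional assay on MCF7 cells (Homo sapiens) for antiproliferative activity, read by MTT assay, with a stated time of 24 h; on this read-out lower numbers stand for stronger inhibition and higher numbers for weaker inhibition. Compound 1 gives only a limit there, > 100000 nM, not a number. Compound 3 likewise gives only a limit, > 100000 nM. Within the data shown here, that leaves compound 2 as the one compound with an actual number, 24000 nM, and it therefore stands alone; the other two sit at the limit of > 100000 nM in this assay, at which 2 of the 3 values shown sit, so nothing can be said about how far apart they really are.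

Compound 4, `O=C1NC(O)(CCn2cc(-c3ccccc3)nn2)C(OCc2ccccc2)=C1OCc1ccccc1`, has not yet been measured. It differs from compound 2 in one place: hydrogen in place of methyl on an aromatic carbon. The methyl is a single carbon at the outer edge of the molecule, far from the shared core, and the rest of the structure is untouched.

Among the measured compounds shown here, with no measured pair of this kind to lean on, the expectation is a small step in this assay, if any, of about a 1.5-fold higher number from compound 2 to compound 4 (0.16 log units; within the scatter), leaning toward weaker rather than stronger inhibition but possibly not beyond the usual scatter. Compound 4 is thus estimated at 35000 nM, somewhere between 10000 nM and 120000 nM.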

Compound 4, half-maximal inhibitory concentration: 20500 nM
Compound 4: the middle estimate sits 1.7-fold (0.23 log units) above what was measured; measured number inside the range.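

In this assay, among these compounds, the first pair of measured compounds that differ in one place gives a 1.2-fold lower number from compound 2 to compound 4 (0.07 log units; within the scatter). On this evidence, methyl and hydrogen cannot be told apart on this aromatic carbon, para to a large group, so 4-methylphenyl and phenyl give values within the usual scatter of each other. Compound 1 and compound 3 each remain at a limit of the assay rather than a number, so no step to either can be read, and this single pair is all that can be said about the position so far: the limit of > 100000 nM in this assay, at which 2 of the 4 values shown sit.

A single small swap shows only how little this one change does, and it does not show how much room the position has. As far as these compounds go, whether a larger or different group on the same aromatic carbon, such as a methoxy group, a chlorine atom, an amine or a carboxylic acid, would move the value beyond the scatter remains open, and so does whether the same swap would behave alike on a different core.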